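The source may report more compounds than this note shows. Statements on the series, on what has been measured and on what is new or still open speak of the compounds shown alone.

Compound 1 `C=CS(=O)(=O)NC/C=C/c1cc(OC)cc(O)c1C(=O)OCC1CCCCC1` sits at the bottom of the three numbers available: in a functional assay on K562 cells (Homo sapiens) for inhibition, read by luminescence, with a stated time of 72 h, tested at 5 uM (a higher number here means more inhibition of growth at the concentration tested, a lower number less inhibition of growth), compound 1 gives 27.4%. Within the data shown here, compound 3 `C=CS(=O)(=O)NC/C=C/c1cc(OC)cc(O)c1C(=O)OC(C)C` gives 36.2%, and compound 2 `CCN(CC)C/C=C/C(=O)NC/C=C/c1cc(OCCc2ccc(F)cc2)cc(O)c1C(=O)OC(C)C` gives 49.8%, the only measured compound whose gap from compound 1 lies beyond the scatter. The step to compound 4 `C=CS(=O)(=O)NC/C=C/c1cc(OC)cc(O)c1C(=O)OCC(C)c1ccccc1` changes the ester side of compound 1: 1-phenylethyl in place of cyclohexyl on a saturated chain carbon bound to an oxygen next to a carbonyl group. Among the measured compounds shown here, only one measured step bears on this position: a number 8.8 percentage points higher from compound 1 to compound 3 (within the scatter), where the whole cyclohexylmethyl gave way to isopropyl without leaving the scatter. Since that change, also on the oxygen next to the carbonyl group, moved the number little, the swap of cyclohexyl for 1-phenylethyl is expected to move it little as well; an estimated step of a number 4.6 percentage points higher from compound 1 to compound 4 (within the scatter) is anticipated, not beyond the scatter. Compound 4 is therefore expected to give 32% in this assay, with a likely range from 18% to 46%.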

Compound 4, percent growth inhibition at one concentration: 16.7%
Compound 4: middle estimate off by 15.3 percentage points, on the high side, outside the stated range (below it).
By their numbers in this assay, from the lowest: compound 4; then compounds 1 and 3 (each within the scatter of the next); then compound 2.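

With 1-phenylethyl in place of cyclohexyl, this assay shows a number 10.7 percentage points lower from compound 1 to compound 4 (beyond the scatter), and with 2-phenylpropyl in place of isopropyl it shows a number 19.5 percentage points lower from compound 3 to compound 4 (beyond the scatter). The ester position therefore does respond to a change of group, which the earlier step between compound 1 and compound 3 had not shown, and among these three esters the number is lowest with the one carrying an aromatic ring. Nothing measured here explains this drop.

The compounds shown leave open whether the drop goes with the aromatic ring itself or with the branched chain that carries it, a question that a benzyl or 2-phenylethyl ester could separate. Going by these compounds, how an ester bearing an amine in its chain would stand also remains open.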